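A nitro group on the hydrazone ring of a thiosemicarbazone

A few compounds are considered here, and "the series" means these few. Any claim that something is new, unique, unknown or untested is made for them only; others in the source may bear on it.

The series rests on a shared thiosemicarbazone core. Compound 1, `COc1ccc(/C=N/NC(=S)NC(C)(C)[C@H]2CC=C(C)CC2)cc1`, carries a methoxy group on the aromatic ring and an aldehyde-derived hydrazone; in a functional assay on HT-29 cells (Homo sapiens) for inhibition, read by sulforhodamine B assay, with a stated time of 48 h (on this read-out higher numbers stand for weaker inhibition of growth and lower numbers for stronger inhibition of growth), compound 1 gives 33600 nM. Compound 2, `CC1=CC[C@H](C(C)(C)NC(=S)N/N=C(\C)c2ccccc2)CC1`, bears an unsubstituted aromatic ring on a ketone-derived hydrazone. In this assay compound 2 gives only > 100000 nM, which is a limit of the assay and not a number, as the limit of > 100000 nM in this assay, at which 1 of the 2 values shown sits, records. Compound 2 therefore stands at the weak end of the two values shown, with no measured figure of its own. Compound 3, `CC1=CC[C@H](C(C)(C)NC(=S)N/N=C(\C)c2ccc([N+](=O)[O-])cc2)CC1`, differs from compound 2 by nitro in place of hydrogen on an aromatic carbon — nitro in place of hydrogen on an aromatic carbon. No measured step of this kind is available among the compounds shown, so the size of the change is open. A modest gain, or none beyond the scatter, is what is expected, with a real chance that the assay again returns only a limit. Compound 3 is estimated to give about 70000 nM, within a range from 20000 nM to 150000 nM. This estimate implies a step of an at least 1.4-fold lower number from compound 2 to compound 3 (0.15 log units; that floor lies within the scatter).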

Compound 3, concentration for total growth inhibition: > 100000 nM
Compound 3 was reported as a limit (the forecaster's own chance of this, stated with the estimate: 50%); at least 1.4-fold (0.15 log units) between middle value and limit.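

In this assay compound 3 gives > 100000 nM, which is a limit of the assay and not a number. Compound 2 also stands at a limit, so the step from compound 2 to compound 3 cannot be read: the limit of > 100000 nM in this assay, at which 2 of the 3 values shown sit. The compounds shown leave open whether nitro in place of hydrogen on an aromatic carbon changes growth inhibition at all, and by how much.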